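The source may hold more compounds than are shown below. What is called first, only, known or untested is meant among the compounds shown, and "the series" means these compounds.

Compound 1: `O=c1cc(-c2ccccc2)oc2cccc(OCCCCN3CCC(O)CC3)c12` — 58 nM
Compound 2: `CN(C)CCCCCCCOc1ccc2oc(-c3ccccc3)cc(=O)c2c1` — 165 nM

Both compounds were tested in an assay on isolated protein (Cavia porcellus) with Sigma non-opioid intracellular receptor 1 (Homo sapiens) as the target, read by radioligand binding; on this read-out higher numbers stand for weaker inhibition and lower numbers for stronger inhibition. Compound 1 gives 58 nM, while compound 2 gives 165 nM. Compound 2 thus stands with the higher of the two numbers, and its gap to compound 1 lies beyond the usual scatter of repeated measurements. Compound 3 `CN(C)CCCCCCCCCCOc1ccc2oc(-c3ccccc3)cc(=O)c2c1` has not yet been measured. It differs from compound 2 in a single place: 3-(dimethylamino)propyl in place of dimethylamino on a saturated chain carbon, seven bonds along the chain from an oxygen on an aromatic ring. For the measured compounds named here, no measured pair shows this kind of change, so any expectation rests only on the two numbers at hand and on the change itself. The expected step is a 1.7-fold lower number from compound 2 to compound 3 (0.22 log units; within the scatter), a slight move toward a lower number that could well sit within the scatter. Compound 3 is therefore estimated at 100 nM, with a plausible range from 35 nM to 300 nM.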

Compound 3, half-maximal inhibitory concentration: 297 nM
Compound 3: the middle estimate sits 3.0-fold (0.47 log units) below what was measured; low and high end bracket the measured number.
By their numbers in this assay, from the lowest: compound 1; then compounds 2 and 3 (each within the scatter of the next).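

In this assay, putting 3-(dimethylamino)propyl in place of dimethylamino at this place on the saturated chain gives a 1.8-fold higher number from compound 2 to compound 3 (0.26 log units; within the scatter). For the compounds shown here, this is the first measured pair to show this change, and the step stays within the scatter even though the group that enters has three more heavy atoms than the one that leaves. On this pair, then, lengthening the chain that carries the dimethylamino group leaves the two numbers indistinguishable, although a single pair sets no rule for other chain lengths.

Still open, on these data alone, is what a shorter group such as 2-(dimethylamino)ethyl at this place, or a morpholine in place of the dimethylamino group at the end of the chain, would do to the number. No measurement shown bears on the reason for the size of this step.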